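Ester to ethyl amide on the shared core: stability outlook

This account rests on a few compounds, and the source may have more. Where it says the series, first, only, none or still open, it means among the compounds named here.

Two compounds of this series have numbers in an ADME assay on microsomes from liver (Homo sapiens) for metabolic stability, read by LC-MS, using NADPH, with a stated time of 45 min, tested at 1 uM; a lower number here means that the compound disappears faster, a higher number that the compound lasts longer. Within the data shown here, compound 1 `COCCOC(=O)c1cc(N)c(Nc2ccc(C#N)cc2)cc1Oc1c(C)cc(/C=C/C#N)cc1C` carries a (2-methoxyethoxy)carbonyl group on the shared core; in this assay compound 1 gives 0.317 h, the higher of the two numbers so far. Compound 2 `Cc1cc(/C=C/C#N)cc(C)c1Oc1cc(Nc2ccc(C#N)cc2)c(N)cc1C(=O)NCCC(F)F` replaces that group with an amide bearing a 3,3-difluoropropyl chain, and in this assay compound 2 gives 0.233 h. Among the measured compounds shown here, the only step available, a 1.4-fold lower number from compound 1 to compound 2 (0.13 log units; within the scatter), is within the scatter, so on present numbers the ester and this amide are not distinguishable.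

Compound 3 `CCNC(=O)c1cc(N)c(Nc2ccc(C#N)cc2)cc1Oc1c(C)cc(/C=C/C#N)cc1C` is the next member. The change from compound 1 is ethylamino in place of 2-methoxyethoxy on a carbonyl carbon. It is the same kind of change as the step to compound 2 (an ester converted to a secondary amide), and that step is the one bearing on it. Since that step, a 1.4-fold lower number from compound 1 to compound 2 (0.13 log units; within the scatter), stayed within the scatter, no step beyond the scatter is expected in this assay here either, in either direction, with the estimate a 1.1-fold lower number from compound 1 to compound 3 (0.02 log units; within the scatter). Compound 3 is therefore expected to give 0.3 h, with a range from 0.15 h to 0.6 h.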

Compound 3, half-life: 2.32 h
Compound 3: the middle estimate sits 7.7-fold (0.89 log units) below what was measured, and the stated range ends below it.
By their numbers in this assay, from the lowest: compounds 2 and 1 (each within the scatter of the next); then compound 3.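

At the carbonyl carbon of the shared core, the result in this assay turns on the particular group and not simply on an ester giving way to an amide: ethylamino in place of 2-methoxyethoxy gives a 7.3-fold higher number from compound 1 to compound 3 (0.86 log units; beyond the scatter), whereas the 3,3-difluoropropyl amide gave only a 1.4-fold lower number from compound 1 to compound 2 (0.13 log units; within the scatter). Within the amides, the end of the chain carries weight: hydrogen in place of difluoromethyl on a saturated chain carbon, two bonds along the chain from an amide-type nitrogen, gives a 10-fold higher number from compound 2 to compound 3 (1.00 log units; beyond the scatter), so the amide linkage alone does not go with the longer half-life, with compound 2 as the case against it. Nothing available here bears on the origin of these differences in half-life.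

Open, as far as these compounds go, is how narrow the range of favourable groups is: methylamino, propylamino or a cyclopropylamino group on the same carbonyl would show whether ethylamino is a special case. A single fluorine or a trifluoromethyl group at the end of the chain, and a tertiary amide such as dimethylamino, would show how far the result depends on the chain end and on the amide hydrogen.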